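This account rests on a few compounds, and the source may have more. Where it says the series, first, only, none or still open, it means among the compounds named here.

Among the compounds with values here, compound 2 `COC[C@H]1CN(c2ccc(-n3cc(-c4ccccn4)cn3)c(F)c2)C(=O)O1` is the only compound here with a plain number: in a physicochemical assay for solubility, read by HPLC, with a stated time of 24 h (on this read-out higher numbers stand for higher solubility and lower numbers for lower solubility), compound 2 gives 36200 nM. Compound 1 `O=C(OC[C@H]1CN(c2ccc(-n3cc(-c4ccccn4)cn3)c(F)c2)C(=O)O1)c1ccccc1` has a benzoyl in place of methyl on an oxygen on a saturated carbon, and its result is a limit, not a number: compound 1 gives <= 65400 nM. The step that the limit leaves unreadable from compound 1 to compound 2 therefore cannot be sized, as the limit of <= 65400 nM in this assay, at which 1 of the 2 values shown sits, shows. Compound 3 `COC(=O)NC[C@H]1CN(c2ccc(-n3cc(-c4ccccn4)cn3)c(F)c2)C(=O)O1` carries (methoxycarbonyl)amino in place of methoxy on a saturated chain carbon bound to a saturated ring carbon. Within the data shown here, no measured step reads on that change, so the estimated step of a 1.0-fold lower number from compound 2 to compound 3 (0.00 log units; within the scatter) is expected to stay within the usual scatter. Compound 3 is accordingly expected to give 36000 nM, within a range from 14000 nM to 90000 nM.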

Compound 3, solubility: 34100 nM
The estimate for compound 3 lay 1.1-fold (0.02 log units) above the measured number; the range from low to high includes it.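

On a saturated chain carbon bound to a saturated ring carbon, putting (methoxycarbonyl)amino in place of methoxy gives a 1.1-fold lower number from compound 2 to compound 3 (0.03 log units; within the scatter) in this assay. Within the data shown here, this is the first step at this position that can be read, and it shows that a group with more heavy atoms and a hydrogen-bond donor can replace methoxy here with no change beyond the scatter. Compound 1 has a limit and not a number, so the steps from it cannot be read: the limit of <= 65400 nM in this assay, at which 1 of the 3 values shown sits.

Going by these compounds, whether an amine, a carboxylic acid or a longer chain at this place would also stay within the scatter of compound 2 remains open. This single pair says nothing about changes elsewhere on the shared core.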